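The compounds below may be only part of what the source reports. "The series", "measured", "known", "first", "only" and "open" are said of these compounds alone.

Compound 1 `COc1ccc(-c2cnc(NC(=O)c3cccnc3)n2C)cc1` was examined in a toxicity assay on THP-1 cells (Homo sapiens) for inhibition; a lower number here means that less compound is tolerated, a higher number that more compound is tolerated. In this assay compound 1 reaches only a limit of the assay, > 100000 nM. Two further compounds of the same kind were measured alongside it. Compound 2 `Cn1c(-c2ccccc2)cnc1NC(=O)c1cccc(Cl)c1` likewise stops at a limit in this assay, namely > 50000 nM. Compound 3 `COc1ccc2c(c1)nc(NC(=O)c1ccc(F)cc1)n2C` also gives a limit in this assay, > 100000 nM. For the measured compounds named here, all three results therefore sit at the limit of > 100000 nM in this assay, at which 2 of the 3 values shown sit, or at the limit of > 50000 nM in this assay, at which 1 of the 3 values shown sits, and compound 1 stands with the majority at the higher of the two limits; since every value is a limit and no step between them has been worked out, nothing more can be read from the three.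

Compound 4 `COc1ccc(-c2cnc(NC(=O)c3ccccc3Br)n2C)cc1` is still to be tested in this assay. Going by the values given here, it differs from compound 1 in one place: 2-bromophenyl in place of pyridin-3-yl on a carbonyl carbon No measured step shows what this swap of a 2-bromophenyl for a pyridin-3-yl on the carbonyl carbon does here. The step from compound 1 to compound 4 is expected to stay within the scatter, a number no higher from compound 1 to compound 4 (the limit leaves the size open), because compound 1 already sits at the limit of > 100000 nM in this assay, at which 2 of the 3 values shown sit, in this assay. Compound 4 is therefore estimated at about 100000 nM in this assay, within a range from 30000 nM to 300000 nM, and most probably as a limit once more rather than a number.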

Compound 4, half-maximal cytotoxic concentration: > 100000 nM
Compound 4: only a limit was reported (the forecaster's own chance of this, stated with the estimate: 80%); the middle value lies on the limit itself.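

Compound 1 and compound 4 both give only a limit of the assay, so no step can be read for 2-bromophenyl in place of pyridin-3-yl. The compounds shown leave open what actual number any of them would give in this assay.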